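The source may report more compounds than this note shows. Statements on the series, on what has been measured and on what is new or still open speak of the compounds shown alone.

Maximal responses in a functional assay on HEK293 cells for agonist activity at Glucose-dependent insulinotropic receptor (Homo sapiens), read by cAMP accumulation, with a stated time of 30 min; on this read-out higher numbers stand for larger maximal responses and lower numbers for smaller maximal responses:

Compound 1 `Cc1cc2c(c(Oc3cccc(NS(=O)(=O)c4ccc(Cl)cc4)c3)n1)C(=O)N(C1CC1)C2=O`: 111%
Compound 2 `Cc1cc2c(c(Oc3cccc(NS(=O)(=O)c4ccc(Cl)cc4)c3)n1)C(=O)N(C1CCCC1)C2=O`: 95%

Compound 1 stands highest of the two numbers in this assay; its nearest neighbour is compound 2, and the step of a number 16 percentage points lower from compound 1 to compound 2 (beyond the scatter) is modest but beyond the scatter. Compound 3 `Cc1cc2c(c(Oc3cccc(NS(=O)(=O)c4ccc(Cl)cc4)c3)n1)C(=O)N(c1ccccc1)C2=O` has not been measured in this assay. It differs from compound 1 by phenyl in place of cyclopropyl on an amide-type nitrogen in a ring. Among the measured compounds shown here, the only measured step that bears on this change is the one from compound 1 to compound 2, where a larger carbocycle took the place of the same cyclopropyl on the same amide-type nitrogen and the maximal response fell modestly. On that basis a modest fall, or no change beyond the scatter, is expected for compound 3 in this assay, as a number 16 percentage points lower from compound 1 to compound 3 (beyond the scatter). Compound 3 is therefore estimated to give 95% in this assay, with a range from 75% to 115%.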

Compound 3, largest response reached (reported as efficacy), in percent of the reference or control that the assay uses: 102%
Compound 3: the middle estimate sits 7 percentage points below what was measured; low and high end bracket the measured number.
By their numbers in this assay, from the lowest: compounds 2, 3 and 1 (each within the scatter of the next, the first and the last beyond it).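

In this assay, the amide-type nitrogen in a ring takes an aromatic ring as well as the non-aromatic carbocycles: phenyl in place of cyclopropyl gives a number 9 percentage points lower from compound 1 to compound 3 (within the scatter) and phenyl in place of cyclopentyl gives a number 7 percentage points higher from compound 2 to compound 3 (within the scatter) in the same series. Compound 3 thus lies within the scatter of both compound 1 and compound 2, although those two lie beyond the scatter of each other, so the fall seen with cyclopentyl does not carry over to phenyl as a clear fall. Nothing available gives a reason for these numbers.

The compounds shown leave open how the maximal response behaves with a benzyl group, a phenyl carrying an amine or a carboxylic acid, or an open chain such as ethyl on this nitrogen. They also leave open how potent any of these compounds is, since only the largest response is given.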